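The source may report more compounds than this note shows. Statements on the series, on what has been measured and on what is new or still open speak of the compounds shown alone.

The study records four compounds built on one shared core. Compound 1 `COc1ccc(Cn2cc(CSC(=S)N3CCN(C(=O)OCc4ccccc4)CC3)nn2)cc1` carries a benzyl group on an oxygen next to a carbonyl group; in a functional assay on PC-3 cells (Homo sapiens) for inhibition, read by MTT assay, with a stated time of 72 h (on this read-out higher numbers stand for weaker inhibition and lower numbers for stronger inhibition), compound 1 gives only a limit, > 128000 nM. Compound 2 `COc1ccc(Cn2cc(CSC(=S)N3CCN(C(=O)OC(C)(C)C)CC3)nn2)cc1` carries tert-butyl in place of that benzyl, and in this assay compound 2 likewise gives only a limit, > 128000 nM. The step that the two limits leave unreadable from compound 1 to compound 2 is therefore unreadable, since both ends sit at the limit of > 128000 nM in this assay, at which 2 of the 3 values shown sit. For the measured compounds named here, compound 3 `Cc1ccc(Cn2cc(CSC(=S)N3CCNCC3)nn2)cc1` bears a 4-methylphenyl group; in this assay compound 3 gives 19800 nM, which is the only number among the three values shown. Compound 4 `COc1ccc(Cn2cc(CSC(=S)N3CCNCC3)nn2)cc1` differs from compound 3 in one place: methoxy in place of methyl on an aromatic carbon. Going by the values given here, no measured step touches this change; the single step recorded concerns a different part of the molecule and cannot be read. With nothing to point either way, compound 4 is expected to stand close to compound 3, with a step of a 1.0-fold higher number from compound 3 to compound 4 (0.00 log units; within the scatter) that is not expected to exceed the scatter. Compound 4 is therefore estimated at 20000 nM, with a range from 8000 nM to 50000 nM.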

Compound 4, half-maximal inhibitory concentration: > 128000 nM
Compound 4: only a limit was reported; the forecaster's own chance of this, stated with the estimate: 10%; middle value at least 6.4-fold (0.80 log units) from the limit.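

In this assay, the change from 4-methylphenyl to 4-methoxyphenyl gives the series its first readable step, an at least 6.4-fold higher number from compound 3 to compound 4 (0.81 log units; beyond the scatter), so this position, untouched by any earlier step, does not tolerate every group placed on it. For the compounds shown here, the reading for compound 4 is a limit and not a number, so the true size of this step stays unknown and compound 3 remains the only compound with a number: the limit of > 128000 nM in this assay, at which 3 of the 4 values shown sit. The steps from compound 1 and from compound 2 to compound 4 cannot be read, any more than the step between compound 1 and compound 2, so the effect of removing benzyloxycarbonyl or tert-butoxycarbonyl from the amine nitrogen in the ring stays hidden.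

The compounds shown leave open whether the weaker inhibition is specific to methoxy or would also appear with another group at this place, such as a hydroxyl, a chlorine atom or a longer alkoxy chain. They also leave open whether a 4-methylphenyl group would bring a compound carrying tert-butoxycarbonyl or benzyloxycarbonyl on that ring nitrogen to a measurable value.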